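The source may hold more compounds than are shown below. What is called first, only, known or untested is meant among the compounds shown, and "the series" means these compounds.

Compound 1, `Cc1ccc(C)c(N2CCN(C(=O)c3oc(C)nc3-c3ccc(Cl)cc3)CC2)c1`: "not active" (no number reported)
Compound 2, `Cc1nc(-c2ccc(Cl)cc2)c(C(=O)N2CCN(c3cccc(C(=O)C(C)C)c3)CC2)o1`: "not active" (no number reported)
Compound 3, `Cc1nc(-c2ccccc2)c(C(=O)N2CCN(c3ccc(F)cc3)CC2)o1`: > 1000 nM

Of the compounds shown here, three built on one shared core have been tested in a functional assay on HL-60 cells (Homo sapiens) for inhibition, read by MTT assay, with a stated time of 72 h; on this read-out higher numbers stand for weaker inhibition and lower numbers for stronger inhibition. Compound 1 gives "not active" (no number reported), with no number reported. Compound 2 likewise gives "not active" (no number reported). For compound 3 the read-out is a limit of the assay, > 1000 nM, not a number, which is the limit of > 1000 nM in this assay, at which 1 of the 3 values shown sits. Compound 1 therefore stands nowhere on a numerical scale: none of the three compounds yields a single value, and nothing measured here separates them from one another.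

Compound 4, `Cc1ccc(C)c(N2CCN(C(=O)c3oc(C)nc3-c3ccccc3F)CC2)c1`, has not yet been measured. It differs from compound 1 in one place: 2-fluorophenyl in place of 4-chlorophenyl on an aromatic carbon. Among the compounds with values here, no measured pair shows what such an exchange does on this core. Since compound 1 gives "not active" (no number reported), the step to compound 4 is expected to be small, without a clear direction, and not beyond the usual scatter. Compound 4 is estimated to give 5000 nM in this assay, most likely in the range from 1000 nM to 50000 nM, with a real chance that only a limit is reported again.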

Compound 4, half-maximal inhibitory concentration: 319 nM
For compound 4 the middle estimate is 16-fold (1.20 log units) above the measured one; measured number outside the range, below it.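

Within the data shown here, compound 4 gives a number, 319 nM, but compound 1 gives none, so no step between compound 1 and compound 4 can be read. The compounds shown leave open how large a change the exchange of 4-chlorophenyl for 2-fluorophenyl makes on the shared core.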